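Shortening the Ester on a Shared Core

A few compounds are considered here, and "the series" means these few. Any claim that something is new, unique, unknown or untested is made for them only; others in the source may bear on it.

compound 1 `CCOC(=O)/C(=C/c1ccccc1)CN1C(=O)[C@@H](OC)[C@H]1c1ccc(F)cc1` — 14000 nM
compound 2 `COC(=O)/C(=C/c1ccccc1)CN1C(=O)[C@@H](OC)[C@H]1c1ccc(OC)cc1` — 14000 nM
compound 3 `COC(=O)/C(=C/c1ccccc1)CN1C(=O)[C@@H](OC)[C@H]1c1ccccc1C(F)(F)F` — 17600 nM

In a functional assay on MDA-MB-231 cells (Homo sapiens) for antiproliferative activity, read by MTT assay, with a stated time of 48 h (a lower number here means a stronger inhibitor, a higher number a weaker inhibitor), compound 1 gives 14000 nM, level at the digits shown with compound 2 and together with it the lowest of the three numbers. The furthest of the three from compound 1 is compound 3, which gives 17600 nM, a gap that lies within the scatter, so all three measured compounds sit in one band.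

Compound 4 `COC(=O)/C(=C/c1ccccc1)CN1C(=O)[C@@H](OC)[C@H]1c1ccc(F)cc1` differs from compound 1 by hydrogen in place of methyl on a saturated chain carbon bound to an oxygen next to a carbonyl group; read one bond further out, the ester changes from ethoxycarbonyl to methoxycarbonyl, while the core and the 4-fluorophenyl group stay as in compound 1.

For the measured compounds named here, none of the measured steps touches the ester. Going by the values given here, the one single-point step, a 1.3-fold higher number from compound 2 to compound 3 (0.10 log units; within the scatter), exchanges the aryl group on the saturated ring carbon and leaves the number within the scatter. Compound 1 and compound 2 differ in both the ester and the aryl group, yet both give the same number at the digits shown. Nothing in these data suggests that trimming ethyl to methyl moves this assay, so compound 4 is expected to show no change at the digits printed from compound 1 to compound 4 (within the scatter). Compound 4 is therefore estimated at 14000 nM, with a range from 7000 nM to 28000 nM.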

Compound 4, half-maximal inhibitory concentration: 21800 nM
Compound 4: middle estimate off by 1.6-fold (0.19 log units), on the low side, and the stated range covers the measured number.
By their numbers in this assay, from the lowest: compounds 1, 2, 3 and 4 (each within the scatter of the next).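

In this assay, for the compounds shown here, the pair of compound 1 and compound 4 gives the first direct reading of the ester, and ethoxycarbonyl to methoxycarbonyl, with hydrogen in place of methyl on a saturated chain carbon bound to an oxygen next to a carbonyl group, gives a 1.6-fold higher number from compound 1 to compound 4 (0.19 log units; within the scatter) on the shared core. Compound 4 also gives two readings of the aryl group with the methoxycarbonyl ester held in common: fluoro in place of methoxy on an aromatic carbon gives a 1.6-fold higher number from compound 2 to compound 4 (0.19 log units; within the scatter) and 4-fluorophenyl in place of 2-(trifluoromethyl)phenyl on a saturated ring carbon gives a 1.2-fold higher number from compound 3 to compound 4 (0.09 log units; within the scatter) so none of these single exchanges separates the compounds beyond the scatter. No independent information on any of these steps is available.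

The compounds shown span only ethyl and methyl at the ester, so whether a longer chain or a carboxylic acid at that place would stay in the same band remains open. On these data alone, on the aryl group, it is equally open how an amine would read.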